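The compounds below may be only part of what the source reports. "The series", "measured", "known", "first", "only" and "open" are said of these compounds alone.

Compound 1 `O=C(/C=C/c1csc2ccccc12)c1cc(Br)ccc1O` and compound 2 `COc1ccc(O)c(C(=O)/C=C/c2csc3ccccc23)c1` share one core. In a functional assay on KB cells (Homo sapiens) for antiproliferative activity, read by sulforhodamine B assay, with a stated time of 72 h (on this read-out higher numbers stand for weaker inhibition and lower numbers for stronger inhibition), compound 1 gives 760 nM and compound 2 gives 640 nM. The change between them, (methoxy in place of bromo on an aromatic carbon), produced a 1.2-fold lower number from compound 1 to compound 2 (0.07 log units; within the scatter). Compound 3 `O=C(/C=C/c1cc2ccccc2s1)c1cc(Br)ccc1O` has the same atoms as compound 1 joined differently; the difference between the two cores is not broken down here. In this assay compound 3 gives > 10000 nM, which is a limit of the assay and not a number. That limit is the limit of > 10000 nM in this assay, at which 1 of the 3 values shown sits. Compound 4 `COc1ccc(O)c(C(=O)/C=C/c2cc3ccccc3s2)c1` carries the same change on the core of compound 3, (methoxy in place of bromo on an aromatic carbon). Because the same change gave only a 1.2-fold lower number from compound 1 to compound 2 (0.07 log units; within the scatter), a small step is expected, and for compound 4 the estimated step is a step that the limit leaves unreadable from compound 3 to compound 4. Compound 4 is therefore expected near 15000 nM, probably between 5000 nM and 50000 nM, with a limit again likely.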

Compound 4, half-maximal inhibitory concentration: > 10000 nM
Compound 4 was reported as a limit (the forecaster's own chance of this, stated with the estimate: 70%); the middle value lies beyond the limit too.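

Compound 3 and compound 4 are both reported only as limits of the assay, so no step between them can be read: the limit of > 10000 nM in this assay, at which 2 of the 4 values shown sit.

As far as these compounds go, whether methoxy in place of bromo does the same on this core as on the core of compound 1 stays open.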